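Isopropyl to tert-butyl from compound 2

This account rests on a few compounds, and the source may have more. Where it says the series, first, only, none or still open, it means among the compounds named here.

In a functional assay on MDA-MB-468 cells (Homo sapiens) for antiproliferative activity, read by sulforhodamine B assay, with a stated time of 4 days (on this read-out higher numbers stand for weaker inhibition of growth and lower numbers for stronger inhibition of growth), compound 2 (`COc1cc(Cl)c(-c2nc(SCC(=O)NC(C)C)nc3[nH]cc(C#N)c23)cc1O`) gives 178 nM and sits in the upper pair of three numbers. Its partner there, compound 1 (`COc1cc(Cl)c(-c2nc(SCC(=O)NC3CC3)nc3[nH]cc(C#N)c23)cc1O`), gives 236 nM within the scatter of compound 2. Compound 3 (`CCNC(=O)CSc1nc(-c2cc(OCC)c(OC)cc2Cl)c2c(C#N)c[nH]c2n1`) gives 64 nM and lies lower, beyond the scatter. Compound 4 (`COc1cc(Cl)c(-c2nc(SCC(=O)NC(C)(C)C)nc3[nH]cc(C#N)c23)cc1O`) carries methyl in place of hydrogen on a saturated chain carbon bound to an amide-type nitrogen and two saturated chain carbons and so reads as isopropyl to tert-butyl. Going by the values given here, the one measured step on this amide substituent is a 1.3-fold lower number from compound 1 to compound 2 (0.12 log units; within the scatter) with isopropyl in place of cyclopropyl, and it stays within the scatter. Among the compounds with values here, compound 3 differs from compound 2 in more than one place and offers no single step. In this assay the expected step is a 1.0-fold lower number from compound 2 to compound 4 (0.02 log units; within the scatter) and none beyond the scatter is foreseen. For compound 4 the estimated value is 170 nM with an expected range from 70 nM to 420 nM as the working window.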

Compound 4, concentration for 50% growth inhibition: 152 nM
Compound 4: the middle estimate sits 1.1-fold (0.05 log units) above what was measured; low and high end bracket the measured number.
By their numbers in this assay, from the lowest: compound 3; then compounds 4, 2 and 1 (each within the scatter of the next).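

In this assay, the amide-type nitrogen also accepts tert-butyl: a 1.2-fold lower number from compound 2 to compound 4 (0.07 log units; within the scatter) and a 1.6-fold lower number from compound 1 to compound 4 (0.19 log units; within the scatter) both stay within the scatter. Methyl in place of hydrogen on this saturated chain carbon therefore adds a further branched group without a step beyond the scatter, and cyclopropyl, isopropyl and tert-butyl read alike here. As far as these compounds go, whether an amine, a carboxylic acid or a longer chain on this nitrogen would also read alike stays open. Nothing available explains why these three groups read alike.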